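This account rests on a few compounds, and the source may have more. Where it says the series, first, only, none or still open, it means among the compounds named here.

Of the compounds shown here, three sharing one core have been measured in a functional assay on SK-MEL-28 cells (Homo sapiens) for cytotoxicity, read by CCK-8 assay, with a stated time of 24 h; on this read-out lower numbers stand for stronger inhibition and higher numbers for weaker inhibition. Compound 1 `COc1ccccc1Oc1c(N)nc(-c2ccccc2)nc1Cl` gives 3140 nM, and compound 2 `COc1ccccc1Oc1c(N)nc(-c2cccc(C)c2)nc1Cl` gives 54000 nM. Compound 3 `COc1ccccc1Oc1c(N)nc(-c2ccccc2)nc1OCCO` gives > 80000 nM, which is a limit and not a number. Compound 3 thus sits at the limit of > 80000 nM in this assay, at which 1 of the 3 values shown sits, and no exact value is available as a starting point. Compound 4 `COc1ccccc1Oc1c(N)nc(-c2cccc(C)c2)nc1OCCO` differs from compound 3 by methyl in place of hydrogen on an aromatic carbon. The same change has been measured once, as a 17-fold higher number from compound 1 to compound 2 (1.24 log units; beyond the scatter), a large step towards weaker inhibition. The other measured step, an at least 25-fold higher number from compound 1 to compound 3 (1.40 log units; beyond the scatter), is also large and runs in the same direction, and compound 4 carries its 2-hydroxyethoxy group as well. On these two steps, no move towards stronger inhibition is expected, and a higher number is the likelier direction. The expected step is a step that the limit leaves unreadable from compound 3 to compound 4. The estimated value for compound 4 is 120000 nM, with an expected range of 45000 nM to 320000 nM.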

Compound 4, half-maximal inhibitory concentration: 14700 nM
Estimate against measurement, compound 4: 8.2-fold (0.91 log units) above, and the stated range ends above it.
By their numbers in this assay, from the lowest: compound 1; then compound 4; then compound 2. At a limit, above all of these: compound 3.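

In this assay, methyl in place of hydrogen on the aromatic carbon, phenyl to 3-methylphenyl, does not act the same way on every core: with 2-hydroxyethoxy it gives an at least 5.4-fold lower number from compound 3 to compound 4 (0.73 log units; beyond the scatter), while with chloro it gave a 17-fold higher number from compound 1 to compound 2 (1.24 log units; beyond the scatter), so the direction of this change depends on the other group: the same change on two cores in this assay, a 17-fold higher number (1.24 log units; beyond the scatter) from compound 1 to compound 2 and an at least 5.4-fold lower number (0.73 log units; beyond the scatter) from compound 3 to compound 4, at least 93-fold (1.97 log units) apart, beyond the scatter of two such steps

Read the other way, 2-hydroxyethoxy in place of chloro gives a 3.7-fold lower number from compound 2 to compound 4 (0.57 log units; beyond the scatter) with 3-methylphenyl, against an at least 25-fold higher number from compound 1 to compound 3 (1.40 log units; beyond the scatter) with phenyl: the same change on two cores in this assay, an at least 25-fold higher number (1.40 log units; beyond the scatter) from compound 1 to compound 3 and a 3.7-fold lower number (0.57 log units; beyond the scatter) from compound 2 to compound 4, at least 93-fold (1.97 log units) apart, beyond the scatter of two such steps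

From the compounds shown here alone, compound 3 gives > 80000 nM, which is a limit and not a number, so the true size of both steps involving compound 3 remains unknown.

The compounds shown leave open whether this reversal extends beyond chloro and 2-hydroxyethoxy, for instance to an amine or a longer chain in their place. They also leave open whether ethyl on the phenyl ring would follow methyl.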